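The compounds below may be only part of what the source reports. "The series", "measured", "known", "first", "only" and "open" are said of these compounds alone.

In an ADME assay for permeability, using PAMPA, with a stated time of 4 h, at pH 7.4 (a higher number here means that the compound crosses the layer faster, a lower number that the compound crosses the layer more slowly), compound 1 (`NCCCCN(C[C@@H]1Cc2cccnc2CN1)[C@H]1CCCc2cccnc21`) gives 77 nm/s and compound 2 (`NCCCCN(C[C@@H]1Cc2nccnc2CN1)[C@H]1CCCc2cccnc21`) gives 2 nm/s while compound 3 (`CN(C)CCCCN(C[C@H]1Cc2ncccc2CN1)[C@H]1CCCc2cccnc21`) gives 240 nm/s as the highest of the three numbers, beyond the scatter from both others. No two of these compounds differ in one place only, so no measured step bears directly on the next change. Compound 4 (`c1cnc2c(c1)CN[C@@H](CN(CCCC1CCNCC1)[C@H]1CCCc3cccnc31)C2`) is not yet measured. Its difference from compound 3 is piperidin-4-yl in place of (dimethylamino)methyl on a saturated chain carbon, three bonds along the chain from an amine nitrogen. A downward step of moderate size, probably beyond the scatter, is expected. This expectation rests only on the position of compound 3 at 240 nm/s as the top number and of compound 1 at 77 nm/s as the nearest number under it. The estimated change is a 3.0-fold lower number from compound 3 to compound 4 (0.48 log units; beyond the scatter) on this reading. For compound 4 the estimated value is 80 nm/s with an expected range of 20 nm/s to 250 nm/s in this assay as a rough guide.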

Compound 4, apparent permeability: 24 nm/s
The estimate for compound 4 lay 3.3-fold (0.52 log units) above the measured number; the measured number falls inside the stated range.
By their numbers in this assay, from the lowest: compound 2; then compound 4; then compound 1; then compound 3.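

In this assay, going by these compounds alone, the change from 4-(dimethylamino)butyl to 3-(piperidin-4-yl)propyl gives a 10-fold lower number from compound 3 to compound 4 (1.00 log units; beyond the scatter), the first reading of a difference in one place, and it shows that the chain end is not a silent position in this assay. The entering piperidin-4-yl brings a six-membered non-aromatic ring and a hydrogen-bond donor together, so this single step cannot assign the drop to either one. Nothing measured here accounts for the size of the step.

Still open, from the compounds shown here alone, is whether the ring or the donor carries the change: a 1-methylpiperidin-4-yl in the same place would hold the ring without that donor, and a primary amine on the same chain would hold a donor without the ring. Compound 1 and compound 2 differ from these compounds in more than one place and cannot settle this.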